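Removing the methoxy from compound 2: expected effect

This account rests on a few compounds, and the source may have more. Where it says the series, first, only, none or still open, it means among the compounds named here.

Measured so far:
Compound 1, `CNC[C@@H]1CCN(c2cc3c(cc2F)c(=O)c(C(=O)O)cn3Cc2ccc(-n3cccn3)cc2)C1`: > 200000 nM in an assay on isolated protein for inhibition of DNA topoisomerase 1 (Homo sapiens), with a stated time of 15 min; a higher number here means a weaker inhibitor, a lower number a stronger inhibitor
Compound 2, `CNC[C@@H]1CCN(c2c(F)cc3c(=O)c(C(=O)O)cn(Cc4ccc(-c5ccccc5)cc4)c3c2OC)C1`: 155000 nM in this assay

Among the measured compounds shown here, compound 2 gives the only numerical value in this assay, and that value stands at the weak end of the scale. For compound 1 the result is a limit of this assay, not a number; see (the limit of > 200000 nM in this assay, at which 1 of the 2 values shown sits). For the measured compounds named here, no step between measured compounds that differ in one place exists in this set, so nothing measured tells how a single change shifts the read-out.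

Compound 3, `CNC[C@@H]1CCN(c2cc3c(cc2F)c(=O)c(C(=O)O)cn3Cc2ccc(-c3ccccc3)cc2)C1`, is not yet measured. Compared with compound 2 it carries hydrogen in place of methoxy on an aromatic carbon, that is, hydrogen in place of methoxy on an aromatic carbon. The change leaves the rest of the structure, including the biphenylmethyl substituent shared with compound 2, untouched.

Given that compound 2 already gives 155000 nM, the expected step is a 1.3-fold higher number from compound 2 to compound 3 (0.11 log units; within the scatter), which is not expected to exceed the usual scatter of this assay. Compound 3 is expected to give 200000 nM, within the range 80000 nM to 500000 nM. A result reported only as a limit of this assay is considered quite likely.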

Compound 3, half-maximal inhibitory concentration: 168000 nM
Beside the measured number, compound 3's estimate is 1.2-fold (0.08 log units) above it, within the range that was stated.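

In this assay, among the compounds shown here, the methoxy-to-hydrogen exchange on the aromatic carbon ortho to the 3-((methylamino)methyl)pyrrolidin-1-yl group gives the first readable single-place step in this set: a 1.1-fold higher number from compound 2 to compound 3 (0.03 log units; within the scatter). At this position, therefore, methoxy and hydrogen are not distinguished by this read-out, and both compounds remain at the weak end of the scale. Phenyl in place of 1H-pyrazol-1-yl on an aromatic carbon gives an at least 1.1-fold lower number from compound 1 to compound 3 (0.07 log units; that floor lies within the scatter), a floor only, and this step shows no separation between the two groups; compound 1 stands at a limit of the assay, not a number: the limit of > 200000 nM in this assay, at which 1 of the 3 values shown sits.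

For the compounds shown here, still open is whether a hydroxyl or an amine on this aromatic carbon would shift the number beyond the scatter, since methoxy and hydrogen are the only two groups compared there. Also open, as far as these compounds go, is whether a carboxamide in place of the carboxylic acid, or a simple piperazine in place of the 3-((methylamino)methyl)pyrrolidin-1-yl group, would move any member of the series away from the weak end of the scale.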